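Lactam in place of the basic piperidine on the amide

The compounds below may be only part of what the source reports. "The series", "measured", "known", "first", "only" and "open" are said of these compounds alone.

Measured compounds:
compound 1, `Cn1ccc2ccc(-c3cc(Nc4ccccc4S(=O)(=O)N4CCOCC4)cc4nccnc34)cc21`, 2640 nM 
compound 2, `CN1CCC(NC(=O)c2ccncc2Nc2cc(-c3ccc4ccn(C)c4c3)c3nccnc3c2)CC1`, 19500 nM 

Both were tested in an assay on lysate for inhibition of 6-phosphofructo-2-kinase/fructose-2,6-bisphosphatase 3 (Homo sapiens), with stated times of 0.5 min and 45 min; on this read-out higher numbers stand for weaker inhibition and lower numbers for stronger inhibition. Of the two numbers, compound 2 carries the higher one, and the gap to compound 1 is beyond the scatter, so compound 2 is the weaker inhibitor of this pair.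

Compound 3, `CN1CC(NC(=O)c2ccncc2Nc2cc(-c3ccc4ccn(C)c4c3)c3nccnc3c2)CCC1=O`, is not yet measured. It differs from compound 2 in one place: 1-methyl-6-oxopiperidin-3-yl in place of 1-methylpiperidin-4-yl on an amide-type nitrogen. Among the measured compounds shown here, no step of this kind between measured compounds is available, so nothing here tells how much the number moves. The change is small and sits far from the shared core, so the expected step in this assay from compound 2 to compound 3, a 1.2-fold higher number from compound 2 to compound 3 (0.09 log units; within the scatter), is none beyond the scatter. For compound 3 the expected value is 24000 nM, within a range of 8000 nM to 80000 nM.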

Compound 3, half-maximal inhibitory concentration: 96500 nM
Compound 3: the middle estimate sits 4.0-fold (0.60 log units) below what was measured; measured number outside the range, above it.
By their numbers in this assay, from the lowest: compound 1; then compound 2; then compound 3.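

In this assay, the group on this amide-type nitrogen clearly matters: 1-methyl-6-oxopiperidin-3-yl in place of 1-methylpiperidin-4-yl gives a 4.9-fold higher number from compound 2 to compound 3 (0.69 log units; beyond the scatter) and so weakens inhibition. Each group has one six-membered non-aromatic ring, no hydrogen-bond donors and one hydrogen-bond acceptor, so these shared counts do not account for the change in the number. No measurement shown here gives a reason for this step.

The step combines two differences, the added ring carbonyl and the attachment moved from the 4-yl to the 3-yl position, and the compounds shown do not separate them. Also open, from the compounds shown here alone, is how 1-methylpiperidin-3-yl, or an open chain such as 2-(dimethylamino)ethyl, would read on this amide-type nitrogen.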